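Working notes: the step from compound 3 to compound 4

This account rests on a few compounds, and the source may have more. Where it says the series, first, only, none or still open, it means among the compounds named here.

- Compound 1 `CC1(C)[C@H]2CC[C@]1(C)N(Cc1cn(-c3ccccc3Br)nn1)C(=O)C2`: 150 nM
- Compound 2 `CC1(C)[C@H]2CC[C@]1(C)N(Cc1cn(-c3ccccc3F)nn1)C(=O)C2`: 60 nM
- Compound 3 `CC1(C)[C@H]2CC[C@]1(C)N(Cc1cn(-c3cccc(Cl)c3)nn1)C(=O)C2`: 60 nM

All three values come from a functional assay on HepG2 cells (Homo sapiens) for inhibition, read by MTT assay, with a stated time of 24 h; on this read-out higher numbers stand for weaker inhibition and lower numbers for stronger inhibition. Compound 3 shares the lowest number of the set with compound 2, and the step between them is no change at the digits printed from compound 2 to compound 3 (within the scatter). Compound 4 `Cc1ccc(-n2cc(CN3C(=O)C[C@@H]4CC[C@@]3(C)C4(C)C)nn2)cc1` carries 4-methylphenyl in place of 3-chlorophenyl on an aromatic nitrogen. Among the compounds with values here, no measured compound carries 4-methylphenyl, so the evidence is indirect. The other aryl exchanges gave only modest steps, a 2.5-fold lower number from compound 1 to compound 2 (0.40 log units; beyond the scatter) and a 2.5-fold lower number from compound 1 to compound 3 (0.40 log units; beyond the scatter). In this assay the expected change is therefore none beyond the scatter, with an estimated 1.2-fold higher number from compound 3 to compound 4 (0.07 log units; within the scatter). For compound 4 the expected value is 70 nM, with an estimated range of 30 nM to 170 nM.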

Compound 4, half-maximal inhibitory concentration: 480 nM
Beside the measured number, compound 4's estimate is 6.9-fold (0.84 log units) below it; measured number outside the range, above it.
By their numbers in this assay, from the lowest: compounds 2 and 3 (each within the scatter of the next); then compound 1; then compound 4.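

Within the data shown here, the aryl group on the aromatic nitrogen matters more than the earlier compounds showed: 4-methylphenyl gives an 8.0-fold higher number from compound 3 to compound 4 (0.90 log units; beyond the scatter) and an 8.0-fold higher number from compound 2 to compound 4 (0.90 log units; beyond the scatter), larger than any step among the earlier compounds. The earlier highest number is also passed, with a 3.2-fold higher number from compound 1 to compound 4 (0.51 log units; beyond the scatter). No measurement shown here bears on what lies behind this change.

The compounds shown leave open whether the higher number goes with the methyl group or with its place on the phenyl ring; 3-methylphenyl and 4-chlorophenyl would separate the two.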